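The source may hold more compounds than are shown below. What is called first, only, known or untested is meant among the compounds shown, and "the series" means these compounds.

Measured compounds:
- compound 1, `Cn1c(=O)c2nc(-c3ccc(I)cc3)[nH]c2n(C)c1=O`: 1.3 nM in an assay for binding affinity to adenosine receptor A1 (Bos taurus); a lower number here means a stronger inhibitor, a higher number a weaker inhibitor
- compound 2, `CCc1ccc(-c2nc3c(=O)n(C)c(=O)n(C)c3[nH]2)cc1`: 0.8 nM in this assay
- compound 3, `CCOc1ccc(-c2nc3c(=O)n(C)c(=O)n(C)c3[nH]2)cc1`: 2 nM in this assay

Compound 3 carries the highest of the three numbers, though against compound 1 the gap is only a 1.5-fold higher number from compound 1 to compound 3 (0.19 log units; within the scatter), within the scatter, and against compound 2 it is a 2.5-fold higher number from compound 2 to compound 3 (0.40 log units; beyond the scatter).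

Compound 4, `CCCCOc1ccc(-c2nc3c(=O)n(C)c(=O)n(C)c3[nH]2)cc1`, differs from compound 3 by ethyl in place of hydrogen on a saturated chain carbon, two bonds along the chain from an oxygen on an aromatic ring; read one bond further out, the ethoxy of compound 3 becomes a butoxy.

Within the data shown here, none of the measured steps lengthens a chain. The steps available, a 1.6-fold lower number from compound 1 to compound 2 (0.21 log units; within the scatter) and a 1.5-fold higher number from compound 1 to compound 3 (0.19 log units; within the scatter), both within the scatter, and a 2.5-fold higher number from compound 2 to compound 3 (0.40 log units; beyond the scatter), modest, show that exchanging the group at this aromatic position moves the numbers in this assay only a little. A chain extension is a different kind of change, so the measured steps bear on it only loosely; by analogy no step beyond the scatter is expected, or at most a modest one towards a higher number.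

Compound 4 is therefore expected to give 3 nM in this assay, ranging from 1 nM to 9 nM. From compound 3 this estimated step is a 1.5-fold higher number from compound 3 to compound 4 (0.18 log units; within the scatter).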

Compound 4, half-maximal inhibitory concentration: 4 nM
Estimate against measurement, compound 4: 1.3-fold (0.12 log units) below, within the range that was stated.
By their numbers in this assay, from the lowest: compounds 2, 1, 3 and 4 (each within the scatter of the next, the first and the last beyond it).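

In this assay the only chain extension shown, ethoxy to butoxy, gives a 2.0-fold higher number from compound 3 to compound 4 (0.30 log units; within the scatter) and so adds no step beyond the scatter on its own. Set against the other groups on the aromatic carbon, butoxy does stand apart: the exchange for ethyl gives a 5.0-fold higher number from compound 2 to compound 4 (0.70 log units; beyond the scatter) and the exchange for iodo gives a 3.1-fold higher number from compound 1 to compound 4 (0.49 log units; beyond the scatter) and both steps are modest. The earlier compounds shown here held a single step beyond the scatter at this position, so butoxy widens the spread of the series, though still without a large step.

On these data alone, whether a longer chain such as hexyloxy, or a butoxy chain ending in an amine or a carboxylic acid, would stay within this narrow spread remains open. No measurement at hand offers an explanation for these steps.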